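The source may report more compounds than this note shows. Statements on the series, on what has been measured and on what is new or still open speak of the compounds shown alone.

Compound 3 `O=C(NC(=S)Nc1nc2cc(Br)ccc2s1)N1CCOCC1` gives the lowest of the three numbers recorded so far in a functional assay on HeLa cells (Homo sapiens) for cytotoxicity, read by MTT assay, with a stated time of 24 h (on this read-out lower numbers stand for stronger inhibition and higher numbers for weaker inhibition), at 38900 nM, though its gaps to its neighbours stay within the scatter. Compound 2 `O=C(NC(=S)Nc1nc2ccccc2s1)c1ccccc1` gives 57500 nM in this assay, and compound 1 `Nc1ccc2sc(NC(=S)NC(=O)c3ccccc3)nc2c1` gives 70100 nM. Among the measured compounds shown here, the one single-point step seen, a 1.2-fold lower number from compound 1 to compound 2 (0.09 log units; within the scatter), concerns hydrogen in place of amino on an aromatic carbon and is small. Compound 4 `O=C(NC(=S)Nc1nc2cc(Br)ccc2s1)c1cccs1` differs from compound 3 by thiophen-2-yl in place of morpholin-4-yl on a carbonyl carbon. For the measured compounds named here, no measured step touches the group on the carbonyl carbon, so the only guide is the narrow spread of the three values. On that basis the step from compound 3 to compound 4 is expected to be a 1.0-fold higher number from compound 3 to compound 4 (0.01 log units; within the scatter), none beyond the scatter. Compound 4 is therefore estimated at 40000 nM, within 15000 nM to 100000 nM.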

Compound 4, half-maximal inhibitory concentration: 46500 nM
The estimate for compound 4 lay 1.2-fold (0.07 log units) below the measured number, within the range that was stated.
By their numbers in this assay, from the lowest: compounds 3, 4, 2 and 1 (each within the scatter of the next).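

Among the compounds shown here, the first step at the carbonyl carbon, a 1.2-fold higher number from compound 3 to compound 4 (0.08 log units; within the scatter), shows that in this assay thiophen-2-yl and morpholin-4-yl cannot be told apart on the shared core. A five-membered aromatic ring and a six-membered non-aromatic ring are thus both accommodated at this position without a change beyond the scatter. Nothing measured here accounts for this result. Going by these compounds, whether an open-chain amine, a carboxylic acid or a longer alkyl chain on the carbonyl carbon would move the number beyond the scatter remains open.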